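This account rests on a few compounds, and the source may have more. Where it says the series, first, only, none or still open, it means among the compounds named here.

In a functional assay on A549 cells (Homo sapiens) for antiproliferative activity, read by MTT assay, with a stated time of 72 h (a higher number here means a weaker inhibitor, a lower number a stronger inhibitor), compound 1 `COc1cc(Nc2cccc3c2S(=O)(=O)C=C3)cc(OC)c1OC` gives 950 nM, while compound 2 `O=S1(=O)C=Cc2cccc(Nc3ccc(C(F)(F)F)cc3)c21` gives 2440 nM. This is the higher of the two numbers, so compound 2 is the weaker inhibitor, by a gap beyond the usual scatter. Compound 3 `Cc1ccc(Nc2cccc3c2S(=O)(=O)C=C3)cc1` has not yet been measured. It carries methyl in place of trifluoromethyl on an aromatic carbon. Among the measured compounds shown here, no measured pair shows this exchange, so only a small shift toward a lower number is expected in this assay, probably not beyond the scatter. The estimated step is a 1.6-fold lower number from compound 2 to compound 3 (0.21 log units; within the scatter). Compound 3 is expected at 1500 nM, within an estimated range of 550 nM to 4500 nM.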

Compound 3, half-maximal inhibitory concentration: 2680 nM
Beside the measured number, compound 3's estimate is 1.8-fold (0.25 log units) below it; low and high end bracket the measured number.
By their numbers in this assay, from the lowest: compound 1; then compounds 2 and 3 (each within the scatter of the next).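

In this assay, putting methyl in place of trifluoromethyl on this aromatic carbon, para to a large group, gives a 1.1-fold higher number from compound 2 to compound 3 (0.04 log units; within the scatter) and so leaves the number within the scatter. At this position, then, the two groups cannot be told apart in this assay, despite four heavy atoms leaving and one entering. Nothing measured here offers an explanation for this result.

On these data alone, whether an amine or a carboxylic acid on the same carbon would also read alike remains open. Compound 1 differs from compound 2 and compound 3 in more than one place, so what sets its number apart also stays unresolved.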